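This account rests on a few compounds, and the source may have more. Where it says the series, first, only, none or still open, it means among the compounds named here.

Among the measured compounds shown here, compound 2 `C=CC1=C(C(=O)NCCC)C(c2ccc(OC)cc2)OC1` is one of two compounds so far examined in a functional assay on SW480 cells (Homo sapiens) for cytotoxicity, read by MTT assay, with a stated time of 24 h; on this read-out lower numbers stand for stronger inhibition and higher numbers for weaker inhibition. In this assay compound 2 gives > 100000 nM, which is a limit of the assay and not a number. Its companion, compound 1 `C=CC1=C(C(=O)NCCCCC)C(c2ccc(OC)cc2)OC1`, differs from it only by hydrogen in place of ethyl on a saturated chain carbon, three bonds along the chain from an amide-type nitrogen. In this assay compound 1 gives > 100000 nM, again a limit. The step that the two limits leave unreadable from compound 1 to compound 2 therefore cannot be read, because of the limit of > 100000 nM in this assay, at which 2 of the 2 values shown sit.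

Compound 3 `C=CC1=C(C(=O)Nc2ccc(C)cc2)C(c2ccc(OC)cc2)OC1` has not yet been measured. It differs from compound 2 by 4-methylphenyl in place of propyl on an amide-type nitrogen. No measured step bears on the exchange of propyl for 4-methylphenyl on an amide-type nitrogen; the one step that is shown, between two chain lengths, is unreadable. The change is larger than that between compound 1 and compound 2, so the expectation for compound 3 rests on little. Compound 3 is expected to show a step of a number no higher from compound 2 to compound 3 (the limit leaves the size open), most likely none beyond the scatter, with a chance of a readable number. The estimate for compound 3 is 100000 nM, with a range from 15000 nM to 300000 nM.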

Compound 3, half-maximal inhibitory concentration: > 100000 nM
Compound 3 ended at the assay's limit; the forecaster's own chance of this, stated with the estimate: 65%; the middle value lies on the limit itself.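

In this assay compound 3 gives > 100000 nM, which is a limit of the assay and not a number. Among the compounds shown here, no step linking compound 3 to compound 1 or compound 2 can be read, because all three compounds share that limit: the limit of > 100000 nM in this assay, at which 3 of the 3 values shown sit. The compounds shown leave open whether propyl, pentyl and 4-methylphenyl on the amide-type nitrogen differ at all in this assay.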